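From Phenoxy to Phenylsulfanyl: Expecting Compound 4

A few compounds are considered here, and "the series" means these few. Any claim that something is new, unique, unknown or untested is made for them only; others in the source may bear on it.

Three measured compounds share one common core. Compound 1 `O=C(O)CC/C=C\CC1COC(c2cccs2)OC1c1cccnc1` gives 71 nM in an assay for inhibition of Thromboxane-A synthase (Homo sapiens), using microsomes; a lower number here means a stronger inhibitor, a higher number a weaker inhibitor. Compound 2 `COc1ccc(OC(C)(C)C2OCC(C/C=C\CCC(=O)O)C(c3cccnc3)O2)cc1` gives 41 nM in this assay, and compound 3 `CSc1ccccc1OC(C)(C)C1OCC(C/C=C\CCC(=O)O)C(c2cccnc2)O1` gives 36 nM. Compound 3 holds the lowest of the three numbers, yet its gaps to compound 2 and to compound 1 both lie within the scatter, so no order among them can be claimed. Among the measured compounds shown here, the only step that changes a single place, a 1.1-fold lower number from compound 2 to compound 3 (0.06 log units; within the scatter), shows that exchanging one aromatic group for another at that position left the number within the scatter.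

Compound 4 `CC(C)(Sc1ccccc1)C1OCC(C/C=C\CCC(=O)O)C(c2cccnc2)O1` differs from compound 3 in one place: phenylsulfanyl in place of 2-(methylsulfanyl)phenoxy on a saturated chain carbon bound to two saturated chain carbons and a saturated ring carbon. For the measured compounds named here, no measured pair covers exactly this exchange; the step from compound 2 to compound 3 is the nearest guide, and it stayed within the scatter. The expected step in this assay is therefore small: a 1.1-fold higher number from compound 3 to compound 4 (0.05 log units; within the scatter). The estimate for compound 4 is 40 nM, between 15 nM and 110 nM.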

Compound 4, half-maximal inhibitory concentration: 40 nM
Compound 4: the middle estimate sits on the measured number at the digits printed; the range from low to high includes it.
By their numbers in this assay, from the lowest: compounds 3, 4, 2 and 1 (each within the scatter of the next).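

In this assay, phenylsulfanyl carries no oxygen and has fewer heavy atoms than 2-(methylsulfanyl)phenoxy, yet this exchange gives only a small step (a 1.1-fold higher number from compound 3 to compound 4 (0.05 log units; within the scatter)). The exchange for 4-methoxyphenoxy at the same saturated chain carbon is just as small (a 1.0-fold lower number from compound 2 to compound 4 (0.01 log units; within the scatter)), so among these compounds, an oxygen link to the aromatic ring and a substituent on that ring are not needed to keep the number in this range. The larger exchange on the saturated ring carbon also stays within the scatter (a 1.8-fold lower number from compound 1 to compound 4 (0.25 log units; within the scatter)), so compound 4 cannot be ranked against compound 1 or any other compound shown. Still open, from the compounds shown here alone, is whether a group with no aromatic ring at this place, such as an amine or a plain butyl chain, would move the number beyond the scatter. Nothing measured here explains why these exchanges change so little.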